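Tetrazole series: cyano replacing trifluoromethoxy on the benzyl ring

This account rests on a few compounds, and the source may have more. Where it says the series, first, only, none or still open, it means among the compounds named here.

Working notes on three measured analogues sharing one core. Compound 1 `CNCCN(C)c1nnnn1Cc1ccc(C(F)(F)F)cc1` gives 2% in an assay on cells for inhibition of protein arginine N-methyltransferase 1 (Homo sapiens), read by scintillation counting, with stated times of 15 min and 60 min, tested at 9 uM; a higher number here means more inhibition at the concentration tested (going by the name of the read-out), a lower number less inhibition. Compound 2 `CNCCN(C)c1nnnn1Cc1cccc(OC(F)(F)F)c1` gives 12% in this assay. Compound 3 `CNCCN(C)c1nnnn1Cc1ccc(OC(F)(F)F)cc1` gives 5% in this assay, the second highest of the three, with compound 1 nearest and compound 2 furthest; both gaps lie within the scatter. Among the measured compounds shown here, the one single-point step measured, trifluoromethoxy in place of trifluoromethyl on an aromatic carbon, gave a number 3 percentage points higher from compound 1 to compound 3 (within the scatter), no real movement. Compound 4 `CNCCN(C)c1nnnn1Cc1ccc(C#N)cc1` differs from compound 3 by cyano in place of trifluoromethoxy on an aromatic carbon. For the measured compounds named here, no measured step bears on a cyano group, so nothing beyond the scatter is expected in this assay. Compound 4 is therefore estimated at 5%, range -5% to 15%, a step of no change at the digits printed from compound 3 to compound 4 (within the scatter) expected from compound 3.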

Compound 4, a percentage reported as inhibition, at one concentration (the size of the read-out at that concentration, not a potency): 6%
For compound 4 the middle estimate is 1 percentage points below the measured one; the measured number falls inside the stated range.
By their numbers in this assay, from the lowest: compounds 1, 3, 4 and 2 (each within the scatter of the next).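

In this assay, cyano in place of trifluoromethoxy on this aromatic carbon gives a number 1 percentage points higher from compound 3 to compound 4 (within the scatter) and cyano in place of trifluoromethyl gives a number 4 percentage points higher from compound 1 to compound 4 (within the scatter). This position therefore does not separate the nonfluorinated cyano group from either fluorinated group in this assay, although cyano is the only one of the three with a triple bond. No evidence available here bears on the reason for this result. On these data alone, whether an amine or a carboxylic acid on this aromatic carbon would move the number beyond the scatter remains open. Also open, as far as these compounds go, is how cyano would behave at the ring position carrying trifluoromethoxy in compound 2.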